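Moving the formyl group on the thiophene ring

The compounds below may be only part of what the source reports. "The series", "measured", "known", "first", "only" and "open" are said of these compounds alone.

- compound 1 `Cn1cccc1-c1cncc(Cl)c1N1CCC2(CCNC2=O)CC1`: 900 nM
- compound 2 `O=Cc1sccc1-c1cncc(Cl)c1N1CCC2(CCNC2=O)CC1`: 28700 nM

In a functional assay on MV4-11 cells (Homo sapiens) for inhibition, read by resazurin assay, with a stated time of 72 h (a lower number here means a stronger inhibitor of growth, a higher number a weaker inhibitor of growth), compound 2 holds the higher of the two numbers. For the measured compounds named here, the only measured step is a 32-fold higher number from compound 1 to compound 2 (1.50 log units; beyond the scatter). Compound 3 `O=Cc1cscc1-c1cncc(Cl)c1N1CCC2(CCNC2=O)CC1` has the same atoms as compound 2, joined differently: 4-formylthiophen-3-yl in place of 2-formylthiophen-3-yl on an aromatic carbon. The change lies on an aromatic carbon, ortho to a large group. Going by the values given here, no measured step moves the formyl group, so the large step from the 1-methyl-1H-pyrrol-2-yl group bears only indirectly, as it exchanges the whole group and not the arrangement within it. Compound 1, at 900 nM, is the only lower reference, so a much smaller change is expected here, leaning towards a lower number, with the direction uncertain. The expected step is a 1.9-fold lower number from compound 2 to compound 3 (0.28 log units; within the scatter). For compound 3 the estimated value is 15000 nM, with an expected range of 4000 nM to 50000 nM.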

Compound 3, concentration for 50% growth inhibition: 27100 nM
The estimate for compound 3 lay 1.8-fold (0.26 log units) below the measured number, and the stated range covers the measured number.
By their numbers in this assay, from the lowest: compound 1; then compounds 3 and 2 (each within the scatter of the next).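

In this assay the swap of 2-formylthiophen-3-yl for 4-formylthiophen-3-yl gives a 1.1-fold lower number from compound 2 to compound 3 (0.02 log units; within the scatter) and so leaves the two compounds indistinguishable, which means that between these two arrangements the place of the formyl group on the thiophene does not separate them. The second isomer also stands far from the 1-methyl-1H-pyrrol-2-yl reference, with a 30-fold higher number from compound 1 to compound 3 (1.48 log units; beyond the scatter) and thus a large step of the same kind as a 32-fold higher number from compound 1 to compound 2 (1.50 log units; beyond the scatter) for both formylthiophen-3-yl groups. Nothing available here gives a reason for these steps.

The compounds shown leave open whether the higher numbers go with the thiophene ring itself or with the formyl group. A thiophen-3-yl group without a substituent, or one carrying a carboxylic acid or an aminomethyl group in place of the formyl group, would separate those two readings.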